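This account rests on a few compounds, and the source may have more. Where it says the series, first, only, none or still open, it means among the compounds named here.

Measured so far in a functional assay on LOX IMVI cells (Homo sapiens) for cytotoxicity, read by sulforhodamine B assay, with a stated time of 48 h, tested at 0.1 uM; a lower number here means a stronger effect, a higher number a weaker effect of the compound at the concentration tested:
- compound 1, `COc1cc(-c2cc(/C=C/C(=O)c3ccc(N)cc3)[nH]n2)cc(OC)c1OC`: 99%
- compound 2, `COc1ccc(C(=O)/C=C/c2cc(-c3cc(OC)c(OC)c(OC)c3)n[nH]2)cc1OC`: 92%
- compound 3, `COc1cc(-c2cc(/C=C/C(=O)c3ccc(F)c(F)c3)[nH]n2)cc(OC)c1OC`: 94%

All three compounds leave most of the cells unharmed at this concentration. Compound 1 stands at the top of the three numbers, but the gaps to its neighbours, a number 7 percentage points lower from compound 1 to compound 2 (within the scatter) and a number 5 percentage points lower from compound 1 to compound 3 (within the scatter), are within the scatter, as is the gap a number 2 percentage points higher from compound 2 to compound 3 (within the scatter). Every measured step exchanges the aryl group on the carbonyl carbon, and none of them moved the read-out beyond the scatter.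

Compound 4, `COc1ccc(-c2cc(/C=C/C(=O)c3ccc(N)cc3)[nH]n2)cc1OC`, differs from compound 1 elsewhere: hydrogen in place of methoxy on an aromatic carbon. Among the measured compounds shown here, no measured step touches this ring, so nothing among the three compounds speaks directly to this change. Given that all three measured compounds sit close together near the top of the scale in this assay, the step of a number 3 percentage points lower from compound 1 to compound 4 (within the scatter) is expected to stay within the scatter. Compound 4 is therefore estimated at 96%, within a range of 84% to 106%.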

Compound 4, a percentage reported as activity, at one concentration (the size of the read-out at that concentration, not a potency): 102%
Estimate against measurement, compound 4: 6 percentage points below, and the stated range covers the measured number.
By their numbers in this assay, from the lowest: compounds 2, 3, 1 and 4 (each within the scatter of the next).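

The step of a number 3 percentage points higher from compound 1 to compound 4 (within the scatter) is the first one shown on the methoxy-bearing ring rather than on the aryl group at the carbonyl carbon, and in this assay it also stays within the scatter. Replacing this methoxy, which sits ortho to a methoxy group and meta to a large group, with hydrogen therefore leaves the read-out indistinguishable from that of compound 1 at the concentration tested. Nothing available accounts for this result.

On these data alone, whether a different group at this position, such as an amine or a chlorine atom, would move the read-out beyond the scatter remains open. With all four compounds close together near the top of the scale, the compounds shown also leave open whether this step would matter at a higher concentration.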